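Removing the methoxy group from compound 2

A few compounds are considered here, and "the series" means these few. Any claim that something is new, unique, unknown or untested is made for them only; others in the source may bear on it.

Among the measured compounds shown here, of the two numbers measured so far in a functional assay on HeLa cells (Homo sapiens) for cytotoxicity, read by MTT assay (a higher number here means a weaker inhibitor, a lower number a stronger inhibitor), compound 2 `COc1ccc2[nH]c(-c3ccccc3)c(C(c3c(-c4ccccc4)[nH]c4ccc(Cl)cc34)C3C(=O)NN=C3C)c2c1` stands lowest, and in this assay compound 2 gives 1200 nM. For the measured compounds named here, its only neighbour is compound 1 `CC1=NNC(=O)C1C(c1c(-c2ccccc2)[nH]c2ccc(Cl)cc12)c1c(-c2ccccc2)[nH]c2ccc(Cl)cc12`, which in this assay gives 9500 nM. The two share one core and differ in a single substituent; the step of a 7.9-fold lower number from compound 1 to compound 2 (0.90 log units; beyond the scatter) is methoxy in place of chloro on an aromatic carbon. Compound 3 `CC1=NNC(=O)C1C(c1c(-c2ccccc2)[nH]c2ccccc12)c1c(-c2ccccc2)[nH]c2ccc(Cl)cc12` is not yet measured and differs from compound 2 by hydrogen in place of methoxy on an aromatic carbon. Going by the values given here, no measured step covers this exact change: the one step at hand concerns the same place on the core but exchanges chloro for methoxy, not methoxy for hydrogen. Since the methoxy group was present when the number fell, its removal is expected to cost part of that gain, but hydrogen is also not chloro, so compound 3 is expected to fall between the two measured numbers. The expected step is a 2.5-fold higher number from compound 2 to compound 3 (0.40 log units; beyond the scatter). In this assay compound 3 is estimated at 3000 nM, within 1000 nM to 10000 nM.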

Compound 3, half-maximal inhibitory concentration: 29800 nM
The estimate for compound 3 lay 9.9-fold (1.00 log units) below the measured number, outside the stated range (above it).
By their numbers in this assay, from the lowest: compound 2; then compound 1; then compound 3.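

Hydrogen gives this position its unsubstituted reference in this assay: the step of a 25-fold higher number from compound 2 to compound 3 (1.40 log units; beyond the scatter) is large and the step of a 3.1-fold higher number from compound 1 to compound 3 (0.50 log units; beyond the scatter) is modest, so methoxy and chloro each give a lower number than hydrogen, both beyond the scatter. The earlier step could only rank methoxy against chloro, which left open whether chloro itself gave any gain. The three compounds now fall in the order methoxy, chloro, hydrogen at this one place on the shared core, with compound 3 the weakest of them and most of the span lying between methoxy and hydrogen. Nothing reported for these compounds accounts for that order.

These three groups alone cannot show whether the number depends on the oxygen of the methoxy group or simply on having any group larger than hydrogen at this position, and a hydroxy group, a fluoro group or a longer ether such as ethoxy could help to separate these readings. From the compounds shown here alone, whether an amine or a carboxylic acid would be tolerated here also remains open, as does whether the same order holds at the chloro group that all three compounds keep.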